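This account rests on a few compounds, and the source may have more. Where it says the series, first, only, none or still open, it means among the compounds named here.

Working notes on the series. In a functional assay on NCI-H226 cells (Homo sapiens) for inhibition, read by sulforhodamine B assay, with a stated time of 48 h, tested at 10 uM (a lower number here means less inhibition of growth, a higher number more inhibition of growth at the concentration tested), compound 1 `COc1cc(-c2nc(N)n(CC(=O)Nc3ccc(/C(C)=N\O)cc3)n2)cc(OC)c1OC` gives 5.19% and compound 2 `C/C(=N/O)c1ccc(NC(=O)Cn2nc(-c3ccccc3)nc2N)cc1` gives 3.91%. Compound 3 `c1ccc(-c2nc3sc(-c4ccccc4)cn3n2)cc1` gives 27% in this assay, the highest of the three numbers; its nearest neighbour is compound 1, lower by a margin beyond the scatter, and compound 2 lies furthest, also beyond the scatter.

Compound 4 `Clc1ccc(-c2cn3nc(-c4ccccc4)nc3s2)cc1` awaits measurement in this assay. Among the measured compounds shown here, the single change from compound 3 is chloro in place of hydrogen on an aromatic carbon. For the measured compounds named here, no pair of measured compounds differing in one place is available, so nothing shows how a change of this kind moves this assay here. A small step, no larger than the scatter and if anything upward, is expected: the step from compound 3 to compound 4 in this assay is estimated at a number 4 percentage points higher from compound 3 to compound 4 (within the scatter). Compound 4 is therefore expected near 31%, within 14% to 50%.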

Compound 4, percent growth inhibition at one concentration: 32%
Compound 4: middle estimate off by 1 percentage points, on the low side, within the range that was stated.
By their numbers in this assay, from the lowest: compounds 2 and 1 (each within the scatter of the next); then compounds 3 and 4 (each within the scatter of the next).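

In this assay, among the compounds shown here, chloro in place of hydrogen on an aromatic carbon, para to a large group, gives a number 5 percentage points higher from compound 3 to compound 4 (within the scatter), the first step that isolates a single change. At this position on the core of compound 3, chloro therefore leaves the reading within the scatter of the parent. No measurement bears on the reason for this.

Going by these compounds, whether an amine, a carboxylic acid or a methoxy group at this same position would give a step beyond the scatter remains open. Also open, on these data alone, is whether the same chloro change would behave alike on the core of compound 1.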